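A few compounds are considered here, and "the series" means these few. Any claim that something is new, unique, unknown or untested is made for them only; others in the source may bear on it.

Measured so far in an assay on isolated protein for inhibition of protein kinase C theta type (Homo sapiens), read by TR-FRET, with a stated time of 2 h; a higher number here means a weaker inhibitor, a lower number a stronger inhibitor:
- compound 1 `N#Cc1cnc(NCc2cnccc2C(F)(F)F)cc1NC1CCOCC1`: 900 nM
- compound 2 `CNC(=O)[C@H]1CC[C@@H](Nc2cc(NCc3cnccc3C(F)(F)F)ncc2C#N)CC1`: 27 nM

Going by the values given here, compound 2 holds the lowest of the two numbers measured in this assay; its nearest neighbour is compound 1, and the only step recorded is a 33-fold lower number from compound 1 to compound 2 (1.52 log units; beyond the scatter), a large one beyond the scatter, produced by exchanging oxan-4-yl for 4-(methylcarbamoyl)cyclohexyl on a nitrogen on an aromatic ring.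

Compound 3 `CC1(C)C[C@H](Nc2cc(NCc3cnccc3C(F)(F)F)ncc2C#N)CC[C@@H]1O` differs from compound 2 by 4-hydroxy-3,3-dimethylcyclohexyl in place of 4-(methylcarbamoyl)cyclohexyl on a nitrogen on an aromatic ring. The six-membered carbon ring of compound 2 is kept, while the methylcarbamoyl gives way to a hydroxyl with two methyls on the ring. Among the compounds with values here, the one measured step says only that leaving the oxane ring for a carbon ring was worth a great deal; it does not tell how much of that gain rests on the methylcarbamoyl itself. Compound 3 is therefore expected to give a number above that of compound 2 and well below that of compound 1. The estimated step in this assay is a 3.0-fold higher number from compound 2 to compound 3 (0.47 log units; beyond the scatter). Compound 3 is estimated at 80 nM, expected to fall between 25 nM and 300 nM.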

Compound 3, half-maximal inhibitory concentration: 7 nM
Compound 3: the middle estimate sits 11-fold (1.06 log units) above what was measured, and the stated range ends above it.
By their numbers in this assay, from the lowest: compound 3; then compound 2; then compound 1.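

In this assay, the methylcarbamoyl proves dispensable at this position on a nitrogen on an aromatic ring: 4-hydroxy-3,3-dimethylcyclohexyl in its place gives a 3.9-fold lower number from compound 2 to compound 3 (0.59 log units; beyond the scatter) and thus a further gain rather than a loss. Against the oxan-4-yl compound, the same group gives a 130-fold lower number from compound 1 to compound 3 (2.11 log units; beyond the scatter) and so keeps the advantage of the carbon ring without any amide. No measurement at hand accounts for either step.

The hydroxyl and the two methyls enter together, so their separate shares of the gain remain unresolved, as does the role of the two defined stereocentres. Also open, on these data alone, is whether a primary amine or a carboxylic acid in place of the hydroxyl on the cyclohexyl ring would hold this level in this assay as well.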